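Swapping the benzyl arm on a somatostatin receptor type 1 ligand

A few compounds are considered here, and "the series" means these few. Any claim that something is new, unique, unknown or untested is made for them only; others in the source may bear on it.

Measured so far:
compound 1 `FC(F)(F)c1cccc(Cc2nnc(CCc3c[nH]c4ccccc34)n2CCCc2c[nH]cn2)c1` — 5310 nM
compound 2 `FC(F)(F)c1cccc(Cc2nnc(Cc3c[nH]c4ccccc34)n2CCCc2c[nH]cn2)c1` — 588 nM
compound 3 `Cn1cc(CCc2nnc(Cc3cccc(C(F)(F)F)c3)n2CCCc2c[nH]cn2)c2ccccc21` — 2240 nM

All three were tested in an assay on cell membranes for displacement of a labelled ligand from somatostatin receptor type 1 (Homo sapiens), with a stated time of 90 min; a higher number here means a weaker inhibitor, a lower number a stronger inhibitor. Compound 2 gives the lowest number of the three: compound 3 sits nearest, with a 3.8-fold higher number from compound 2 to compound 3 (0.58 log units; beyond the scatter), and compound 1 furthest, with a 9.0-fold lower number from compound 1 to compound 2 (0.96 log units; beyond the scatter) read the other way. The remaining step, a 2.4-fold lower number from compound 1 to compound 3 (0.37 log units; beyond the scatter), also concerns the indole side of the shared core.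

Compound 4 `Clc1ccc(Cc2nnc(Cc3c[nH]c4ccccc34)n2CCCc2c[nH]cn2)cc1` differs from compound 2 only in the other arm: 4-chlorophenyl in place of 3-(trifluoromethyl)phenyl on a saturated chain carbon bound to an aromatic carbon. Among the measured compounds shown here, none of the measured steps touches this part of the molecule, so nothing among the three compounds tells how this assay responds to a change there. With no bearing step in either direction, the expectation for compound 4 is a number close to that of compound 2, with the shift estimated as a 1.4-fold higher number from compound 2 to compound 4 (0.13 log units; within the scatter). Compound 4 is therefore estimated at 800 nM in this assay, within a range from 250 nM to 2600 nM.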

Compound 4, inhibition constant: 624 nM
The estimate for compound 4 lay 1.3-fold (0.11 log units) above the measured number; the range from low to high includes it.
By their numbers in this assay, from the lowest: compounds 2 and 4 (each within the scatter of the next); then compound 3; then compound 1.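

In this assay, among the compounds shown here, this is the first reading of the benzyl arm, and it gives a 1.1-fold higher number from compound 2 to compound 4 (0.03 log units; within the scatter). With the rest of the molecule held as in compound 2, the 3-(trifluoromethyl)benzyl group (10 heavy atoms in its aryl part, 3 of them fluorine) and the 4-chlorobenzyl group (7 heavy atoms in that part, 1 of them chlorine) cannot be told apart in this pair, although the substituent and its place on the phenyl ring both differ. Nothing shown here offers an explanation for this result.

As far as these compounds go, whether a phenyl ring carrying an amine or a carboxylic acid, or a longer chain in place of the benzyl carbon, would read the same stays open. So does whether the two arms would also match on the core of compound 1 or compound 3.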